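Adding a nitrile to the biaryl ring of compound 1

A few compounds are considered here, and "the series" means these few. Any claim that something is new, unique, unknown or untested is made for them only; others in the source may bear on it.

Compound 1 `Cc1nn(-c2ccccn2)c2cc(-c3ccc(CCC(=O)O)cc3)ccc12` — 1400 nM
Compound 2 `Cc1nn(-c2ccccn2)c2cc(-c3ccc(CC(C)(C)C(=O)O)cc3)ccc12` — > 100000 nM
Compound 3 `Cc1nn(-c2ccccn2)c2cc(-c3ccc(CCC(=O)O)cc3)ncc12` — 9200 nM

Of the compounds shown here, three have been measured in a functional assay on cells for agonist activity at Free fatty acid receptor 1 (Mus musculus), read by FLIPR and calcium flux, with a stated time of 5 min; on this read-out lower numbers stand for an effect already at smaller amounts and higher numbers for an effect only at larger amounts of compound. Compound 1 gives 1400 nM, the lowest of the two numbers shown; compound 3 gives 9200 nM. For compound 2 only a limit is recorded, > 100000 nM. For the measured compounds named here, the one measured step between compounds that differ in a single place, an at least 71-fold higher number from compound 1 to compound 2 (1.85 log units; beyond the scatter), can only be given as a lower bound because of the limit of > 100000 nM in this assay, at which 1 of the 3 values shown sits.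

Compound 4 `Cc1nn(-c2ccccn2)c2cc(-c3ccc(CCC(=O)O)cc3C#N)ccc12` differs from compound 1 by cyano in place of hydrogen on an aromatic carbon. Going by the values given here, no measured step bears directly on this change: the step from compound 1 to compound 2 concerns the chain, and the pair compound 1 and compound 3 differs in the core. With nothing in the data pointing either way, the author expects a step of no size beyond the scatter, a 1.4-fold higher number from compound 1 to compound 4 (0.15 log units; within the scatter). Compound 4 is estimated at 2000 nM, with a range from 500 nM to 8000 nM.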

Compound 4, half-maximal effective concentration: 6100 nM
Estimate against measurement, compound 4: 3.1-fold (0.48 log units) below, and the stated range covers the measured number.
By their numbers in this assay, from the lowest: compound 1; then compounds 4 and 3 (each within the scatter of the next). At a limit, above all of these: compound 2.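

For the compounds shown here, compound 1's aromatic ring of carbon only had not been changed in the earlier compounds, which varied only the chain and the core. Cyano in place of hydrogen, on the carbon ortho to a large group and meta to the 2-carboxyethyl group, gives a 4.4-fold higher number from compound 1 to compound 4 (0.64 log units; beyond the scatter) in this assay. This position therefore responds to substitution, and this change moves the number upward, although only one group at one carbon is shown and no reason for the step can be given from the data here.

On these data alone, it remains open whether a fluorine atom, a methyl group or a methoxy group on the same carbon would give a similar step. As far as these compounds go, it is equally open whether cyano on another carbon of that ring would do so.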